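Pyridinyl Hydrazone Analogue: Estimating Cytotoxicity of Compound 4

This account rests on a few compounds, and the source may have more. Where it says the series, first, only, none or still open, it means among the compounds named here.

Compound 1 `COc1cc2c(Oc3ccc(NC(=O)N/N=C/c4ccc(C(F)(F)F)cc4)cc3F)ccnc2cc1OCCCN1CCCCC1`: 1100 nM
Compound 2 `COc1cc2c(Oc3ccc(NC(=O)N/N=C/c4ccc(Cl)cc4Cl)cc3F)ccnc2cc1OCCCN1CCCCC1`: 750 nM
Compound 3 `COc1ccc(/C=N/NC(=O)Nc2ccc(Oc3ccnc4cc(OCCCN5CCCCC5)c(OC)cc34)c(F)c2)c(OC)c1`: "not determined" (no result reported)

These compounds were tested in a functional assay on MDA-MB-231 cells (Homo sapiens) for cytotoxicity, read by MTT assay, with a stated time of 72 h; a higher number here means a weaker inhibitor, a lower number a stronger inhibitor. Compound 3 stands nowhere on the numbers: its result was not determined. Compound 4 `COc1cc2c(Oc3ccc(NC(=O)N/N=C/c4ccncc4)cc3F)ccnc2cc1OCCCN1CCCCC1` differs from it by pyridin-4-yl in place of 2,4-dimethoxyphenyl on a carbon with a double bond to nitrogen. Within the data shown here, the only measured step, a 1.5-fold lower number from compound 1 to compound 2 (0.17 log units; within the scatter), also swaps the group on that same carbon and lies within the scatter, but neither of its groups is the one leaving or entering here, so no measured step bears directly on this change. Compounds 1 and 2 sit close together, which hints that the group on this carbon may move the number little. Compound 4 is therefore expected to land near 1000 nM, with an estimated range from 300 nM to 3500 nM.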

Compound 4, half-maximal inhibitory concentration: 1400 nM
Compound 4: the middle estimate sits 1.4-fold (0.15 log units) below what was measured; measured number inside the range.
By their numbers in this assay, from the lowest: compounds 2, 1 and 4 (each within the scatter of the next).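

In this assay, pyridin-4-yl on the carbon with a double bond to nitrogen gives a 1.9-fold higher number from compound 2 to compound 4 (0.27 log units; within the scatter) and a 1.3-fold higher number from compound 1 to compound 4 (0.10 log units; within the scatter), both small steps. A six-membered aromatic ring with a hetero atom therefore cannot be told apart at this place from the 2,4-dichlorophenyl and 4-(trifluoromethyl)phenyl rings, which have carbon only. The step from compound 3 cannot be read, since compound 3 has no number. Still open, going by these compounds, is whether a non-aromatic group on this carbon, such as an amine or a carboxylic acid, would move the number beyond the scatter. No measurement shown here explains why these three compounds sit so close.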